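This account rests on a few compounds, and the source may have more. Where it says the series, first, only, none or still open, it means among the compounds named here.

Compound 1 `O=S(=O)(Nc1ccc(-c2nc3ccccc3o2)cc1)c1cccc(Cl)c1` and compound 2 `Cc1cccc(S(=O)(=O)Nc2ccc3oc(-c4ccccc4)nc3c2)c1` have both been tested in an assay on isolated protein for inhibition of malate dehydrogenase, mitochondrial (Sus scrofa), with stated times of 45 min and 30 min; a higher number here means a weaker inhibitor, a lower number a stronger inhibitor. Compound 1 returns only the limit > 63000 nM, not a number. Compound 2 likewise returns only the limit > 63000 nM. Compound 2 therefore stands at the limit, where both values shown sit (the limit of > 63000 nM in this assay, at which 2 of the 2 values shown sit). Compound 3 `O=S(=O)(Nc1ccc2oc(-c3ccccc3)nc2c1)c1cccc(Cl)c1` differs from compound 2 by one change: chloro in place of methyl on an aromatic carbon. Because both measured compounds give only limits (the limit of > 63000 nM in this assay, at which 2 of the 2 values shown sit), no step beyond the scatter is expected in this assay. Compound 3 is expected to give 100000 nM, between 40000 nM and 300000 nM, most likely again as a limit. The expected step that the limit leaves unreadable from compound 2 to compound 3 stays within the scatter.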

Compound 3, half-maximal inhibitory concentration: > 63000 nM
Compound 3 gave a limit, no number (the forecaster's own chance of this, stated with the estimate: 85%); the middle value does not contradict the limit.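

In this assay, going by these compounds alone, compound 2 and compound 3 both give only a limit, not a number, so no step between them can be read: the limit of > 63000 nM in this assay, at which 3 of the 3 values shown sit. The compounds shown leave open whether any related compound would give a readable number in this assay.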